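A few compounds are considered here, and "the series" means these few. Any claim that something is new, unique, unknown or untested is made for them only; others in the source may bear on it.

Measured compounds in an ADME assay for inhibition of Bile salt export pump (Homo sapiens), read by scintillation counting, with a stated time of 5 min; on this read-out higher numbers stand for weaker inhibition and lower numbers for stronger inhibition:
- compound 1 `N[C@H]1CCN(c2ccc3c(C(=O)NCC4CCCCC4)c(Cl)ccc3n2)C1`: 107000 nM
- compound 2 `CC(C)(C)C(=O)CN1CC2CN(CCCNc3ccc(C#N)cc3)CC(C1)O2`: 514000 nM
- compound 3 `CN(C)C(=O)c1ccc(S(=O)(=O)c2ccc(NC(=O)[C@@](C)(O)C(F)(F)F)c(Cl)c2)cc1`: < 12900 nM

Of the three, compound 1 and compound 2 give numbers, while compound 3 gives only a limit in this assay: the value for compound 3, < 12900 nM, is a limit of the assay and not a number, so where compound 3 truly stands is known only as far as the limit of < 12900 nM in this assay, at which 1 of the 3 values shown sits, tells. For the measured compounds named here, no two measured compounds differ in a single place, so no measured step exists here to lean on.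

Compound 4 `C[C@@](O)(C(=O)Nc1ccc(S(=O)(=O)c2ccc(NCCO)cc2)cc1Cl)C(F)(F)F` is not yet measured. It differs from compound 3 in one place: (2-hydroxyethyl)amino in place of dimethylcarbamoyl on an aromatic carbon. Going by the values given here, with no measured step to set the size, only a modest move is expected, and the direction is left open: the expected step is an at least 1.1-fold higher number from compound 3 to compound 4 (0.06 log units; that floor lies within the scatter). Compound 4 is therefore expected near the limit seen for compound 3, with a fair chance that this assay again reports only a limit. Compound 4 is estimated at 15000 nM, with a range from 4000 nM to 60000 nM.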

Compound 4, half-maximal inhibitory concentration: 27400 nM
The estimate for compound 4 lay 1.8-fold (0.26 log units) below the measured number; the measured number falls inside the stated range.
By their numbers in this assay, from the lowest: compound 4; then compound 1; then compound 2. At a limit, below all of these: compound 3.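

At this position, on an aromatic carbon para to a large group, putting (2-hydroxyethyl)amino in place of dimethylcarbamoyl gives, in this assay, an at least 2.1-fold higher number from compound 3 to compound 4 (0.32 log units; beyond the scatter), which means weaker inhibition. For the compounds shown here, the earlier compounds held no pair differing in one place, so this is the first sign that the read-out responds to a change at this position, and its direction is now fixed rather than open. The step's size is only a floor, since compound 3 has a limit and not a number: the limit of < 12900 nM in this assay, at which 1 of the 4 values shown sits.

The compounds shown leave open whether the step follows from losing dimethylcarbamoyl or from gaining (2-hydroxyethyl)amino, and how far the true step extends past its floor. They also leave open how this position would respond to a plain amine, a carboxylic acid or a longer chain ending in a hydroxyl.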